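The compounds below may be only part of what the source reports. "The series", "measured", "known", "first", "only" and "open" are said of these compounds alone.

Among the measured compounds shown here, compound 1 `O=C(Nc1ccc(OC(F)(F)F)c(F)c1)NC1CCN(C(=O)C2CCOCC2)CC1` is one of two compounds measured in a physicochemical assay for lipophilicity, read by HPLC, with a stated time of 90 min, tested at 100 uM (on this read-out lower numbers stand for lower lipophilicity and higher numbers for higher lipophilicity), where compound 1 gives 3.73. For the measured compounds named here, its only companion is compound 2 `O=C(Nc1ccc(C(F)(F)F)c(F)c1)NC1CCN(C(=O)C2CCOCC2)CC1`, which in this assay gives 3.52; the change of trifluoromethyl in place of trifluoromethoxy on an aromatic carbon brings a number 0.21 log units lower from compound 1 to compound 2 (within the scatter), so the two numbers are indistinguishable, and compound 1 merely holds the larger of the two figures.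

Compound 3 `O=C(Nc1ccc(OC(F)(F)F)c(F)c1)NC1CCN(C(=O)[C@@H]2CCOC2)CC1` has not yet been measured. It differs from compound 1 by oxolan-3-yl in place of oxan-4-yl on a carbonyl carbon. Going by the values given here, no measured step touches this part of the molecule: the one step available concerns the aromatic substituent, not the group on the carbonyl carbon, so it gives no direct guide. What remains is that the group entering carries one heavy atom fewer than the group leaving, with the same count of donors and acceptors. On that basis compound 3 is expected to land somewhat lower, at an estimated 3.35, with a plausible range from 3 to 3.7. The expected step is a number 0.38 log units lower from compound 1 to compound 3 (beyond the scatter), which would just exceed the scatter, though a result inside the scatter would not surprise.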

Compound 3, partition coefficient: 3.59
For compound 3 the middle estimate is 0.24 log units below the measured one; low and high end bracket the measured number.
By their numbers in this assay, from the lowest: compounds 2, 3 and 1 (each within the scatter of the next).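

Among the compounds shown here, this is the first look at the group on the carbonyl carbon, as the earlier pair differed only in the aromatic substituent. In this assay, placing oxolan-3-yl where oxan-4-yl stood gives a number 0.14 log units lower from compound 1 to compound 3 (within the scatter), so this read-out does not separate the six-membered ring from the five-membered ring, even though the entering group has one heavy atom fewer and a defined stereocentre. No measurement shown here offers an explanation for this result.

As far as these compounds go, both groups seen on this carbonyl carbon so far are non-aromatic rings with one hetero atom, so it remains open how this assay would read with a different kind of group in that place, such as a cyclohexyl ring with no oxygen, a ring carrying an amine or a carboxylic acid, or an open carbon chain. Also open, from the compounds shown here alone, are whether the opposite stereocentre on oxolan-3-yl would read the same, and whether this ring swap would give a similar step with trifluoromethyl on the aromatic ring in place of trifluoromethoxy.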